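From Methyl to Methoxy: Expecting a Weaker Amide

The source may hold more compounds than are shown below. What is called first, only, known or untested is meant among the compounds shown, and "the series" means these compounds.

Compound 1 `Cc1cc(C)c(CN2CCc3c(Cl)cc(-c4cn[nH]c4)c(Cl)c3C2=O)c(=O)[nH]1` in an assay on Sf9 cells for inhibition of histone-lysine N-methyltransferase EZH2 (Homo sapiens), read by scintillation counting, with a stated time of 60 min, in the presence of a further agent that is not named here (a higher number here means a weaker inhibitor, a lower number a stronger inhibitor), gives 51 nM.
Compound 2 `Cc1cc(C)c(CNC(=O)c2cccc(OC(C)C)c2C)c(=O)[nH]1` in this assay gives 1400 nM.
Compound 3 `COc1cccc(C(=O)NCc2c(C)cc(C)[nH]c2=O)c1C` in this assay gives 5700 nM.

Compound 3 gives the highest number of the three, so it is the weakest inhibitor shown; its nearest neighbour is compound 2, and the gap to compound 1 is far wider. Among the measured compounds shown here, only one single-point step is available among the measured compounds, the one from compound 2 to compound 3: a 4.1-fold higher number from compound 2 to compound 3 (0.61 log units; beyond the scatter). That change sits on the oxygen of the group that compound 4 keeps, not at the carbon that now changes.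

Compound 4 `COc1cccc(C(=O)NCc2c(C)cc(C)[nH]c2=O)c1OC` differs from compound 3 in one place: methoxy in place of methyl on an aromatic carbon. For the measured compounds named here, no measured pair shows exactly this exchange, so the expectation rests on the single step seen on this ring, from compound 2 to compound 3, which made the inhibitor weaker. A further alteration on the same ring is expected to move in the same direction or to stay within the scatter. Compound 4 is therefore estimated to give 9000 nM in this assay, with a plausible range from 3000 nM to 30000 nM. This expected step, a 1.6-fold higher number from compound 3 to compound 4 (0.20 log units; within the scatter), would leave compound 4 as the weakest of the four.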

Compound 4, half-maximal inhibitory concentration: > 140000 nM
Compound 4 was reported as a limit; the forecaster's own chance of this, stated with the estimate: 20%; middle value at least 15-fold (1.19 log units) from the limit.
By their numbers in this assay, from the lowest: compound 1; then compound 2; then compound 3. At a limit, above all of these: compound 4.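

This aromatic carbon, ortho to a large group and ortho to a methoxy group, tolerates far less change than the oxygen substituent on the same ring: the exchange of methyl for methoxy here gives an at least 24-fold higher number from compound 3 to compound 4 (1.39 log units; beyond the scatter), whereas the earlier exchange on the oxygen gives a 4.1-fold higher number from compound 2 to compound 3 (0.61 log units; beyond the scatter). Compound 4 is reported in this assay only as a limit, > 140000 nM. The step is therefore a minimum and not a true size, yet it still shows that replacing this one methyl with methoxy is enough to lose the measurable inhibition that compound 3 retains: the limit of > 140000 nM in this assay, at which 1 of the 4 values shown sits.

Whether a fluorine, an ethyl group or an amine on this carbon would behave like the methyl of compound 3 or like the methoxy of compound 4 remains open, so the compounds shown cannot say whether the added oxygen or simply the larger group matters. Also open, from the compounds shown here alone, is whether the same exchange would prove as damaging in a compound carrying the isopropyl group of compound 2, or on the core of compound 1.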